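Moving the bromine from compound 3 to compound 4

The source may report more compounds than this note shows. Statements on the series, on what has been measured and on what is new or still open speak of the compounds shown alone.

In a functional assay on K562/A02 cells (Homo sapiens) for antiproliferative activity, read by MTT assay (a higher number here means a weaker inhibitor, a lower number a stronger inhibitor), compound 1 `O=C(CCCCCNC(=S)N/N=C(\c1ccccc1)c1ccccn1)NO` gives 2030 nM, compound 2 `Cc1ccccc1/C(=N/NC(=S)NCCCCCC(=O)NO)c1ccccc1` gives 4220 nM and compound 3 `C/C(=N\NC(=S)NCCCCCC(=O)NO)c1ccc(Br)cc1` gives 440 nM, the lowest of the three and beyond the scatter from both others. Compound 4 `C/C(=N\NC(=S)NCCCCCC(=O)NO)c1cccc(Br)c1` differs from compound 3 by 3-bromophenyl in place of 4-bromophenyl on a carbon with a double bond to nitrogen. Among the compounds with values here, the only measured step, a 2.1-fold higher number from compound 1 to compound 2 (0.32 log units; beyond the scatter), exchanges other groups at such a carbon and was modest. Within the data shown here, no measured step moves a bromine, so it bears only loosely. Compound 3 already sits lowest at 440 nM, so a further drop seems the less likely outcome. The expected step is a 1.8-fold higher number from compound 3 to compound 4 (0.26 log units; within the scatter), a modest rise. For compound 4 the estimated value is 800 nM, with an expected range of 280 nM to 2200 nM.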

Compound 4, half-maximal inhibitory concentration: 520 nM
Compound 4: middle estimate off by 1.5-fold (0.19 log units), on the high side; low and high end bracket the measured number.
By their numbers in this assay, from the lowest: compounds 3 and 4 (each within the scatter of the next); then compound 1; then compound 2.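

In this assay, within the data shown here, 3-bromophenyl in place of 4-bromophenyl on a carbon with a double bond to nitrogen gives a 1.2-fold higher number from compound 3 to compound 4 (0.07 log units; within the scatter), the first step here that keeps the same atoms and only joins them differently. These two bromine placements therefore cannot be told apart in this read-out. Nothing available explains this result. Still open, from the compounds shown here alone, is whether an amine or a methoxy group in place of the bromine would give a comparable number. Also open, going by these compounds, is what a longer chain in place of the saturated chain carbon would do.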